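The source may hold more compounds than are shown below. What is called first, only, known or untested is meant among the compounds shown, and "the series" means these compounds.

Measured compounds in the series:

compound 1, `CC(=O)Nc1ccc(S(=O)(=O)Oc2ccccc2I)cc1`, 17000 nM
compound 2, `CCCC(=O)Nc1ccc(S(=O)(=O)Oc2ccccc2C(C)C)cc1`, 950 nM
compound 3, `CCCC(=O)Nc1ccc(S(=O)(=O)Oc2ccccc2I)cc1`, 2000 nM

All three numbers come from a functional assay on HT-1080 cells (Homo sapiens) for antiproliferative activity, read by sulforhodamine B assay, with a stated time of 48 h; on this read-out lower numbers stand for stronger inhibition and higher numbers for weaker inhibition. Compound 2 gives the lowest number of the three; compound 3 sits nearest to it and compound 1 furthest, both gaps beyond the scatter. Compound 1 and compound 3 share a core and differ in one place, (ethyl in place of hydrogen on a saturated chain carbon bound to a carbonyl carbon), and that change gave an 8.5-fold lower number from compound 1 to compound 3 (0.93 log units; beyond the scatter). Compound 2 and compound 3 also differ in one place, and the step between them is a 2.1-fold higher number from compound 2 to compound 3 (0.32 log units; beyond the scatter). The difference between the cores of compound 1 and compound 2 is not broken down here.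

Compound 4, `CCCCCC(=O)Nc1ccc(S(=O)(=O)Oc2ccccc2C(C)C)cc1`, is not yet measured. It differs from compound 2 in one place, (ethyl in place of hydrogen on a saturated chain carbon, three bonds along the chain from a carbonyl carbon). Within the data shown here, this is the same kind of change as the one from compound 1 to compound 3, but the place is not the same: there the entering ethyl sat on a saturated chain carbon bound to a carbonyl carbon, here it sits on a saturated chain carbon three bonds along the chain from a carbonyl carbon, so the chain grows further out rather than at the carbonyl. Given that the earlier step was an 8.5-fold lower number from compound 1 to compound 3 (0.93 log units; beyond the scatter), a step in the same direction is expected from compound 2 to compound 4 in this assay, but a smaller one, estimated as a 1.6-fold lower number from compound 2 to compound 4 (0.20 log units; within the scatter), since the gain from lengthening may not repeat in full at a more distant place and compound 2 already stands at 950 nM. Compound 4 is therefore expected to give about 600 nM, with a range from 200 nM to 2000 nM.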

Compound 4, half-maximal inhibitory concentration: 6300 nM
The estimate for compound 4 lay 11-fold (1.02 log units) below the measured number; the whole stated range lies below it.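

In this assay the entering ethyl gave a 6.6-fold higher number from compound 2 to compound 4 (0.82 log units; beyond the scatter), so the gain seen when the chain grew on the core of compound 1 did not carry over to the core of compound 2. Set side by side, the two steps run in opposite directions and do not agree: the same change on two cores in this assay, an 8.5-fold lower number (0.93 log units; beyond the scatter) from compound 1 to compound 3 and a 6.6-fold higher number (0.82 log units; beyond the scatter) from compound 2 to compound 4, 56-fold (1.75 log units) apart, beyond the scatter of two such steps
This does not show which difference decides the direction: the two steps differ both in the place of the entering ethyl and in the group held by each core, iodo in compound 1 and isopropyl in compound 2, and a single pair on each core cannot separate the two or define a general trend with chain length.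

The compounds shown leave open how a pentyl chain behaves on the iodo core, a comparison that would set the place of the change apart from the difference between iodo and isopropyl. Also open, from the compounds shown here alone, is how a butyl chain would fall relative to the propyl chain of compound 2 and the pentyl chain of compound 4, and whether a chain longer than pentyl would continue the same direction.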